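This account rests on a few compounds, and the source may have more. Where it says the series, first, only, none or still open, it means among the compounds named here.

- Compound 1 `CC(C)(C)n1cc2c(n1)C(=O)CC1(CCN(C(=O)c3cc(-c4ccc(F)cc4)nc4ccccc34)CC1)O2`: > 10000 nM (a limit)
- Compound 2 `CC(C)(C)n1cc2c(n1)C(=O)CC1(CCN(C(=O)c3cc(-c4ccncc4)nc4ccccc34)CC1)O2`: 1650 nM

Going by the values given here, in a functional assay on MDA-MB-231 cells (Homo sapiens) for inhibition, read by MTT assay, with a stated time of 72 h (on this read-out higher numbers stand for weaker inhibition and lower numbers for stronger inhibition), compound 2 gives 1650 nM, the only actual number so far. The value for compound 1 is a limit. Compound 3 `CCOc1cc(C(=O)N2CCC3(CC2)CC(=O)c2nn(C(C)(C)C)cc2O3)c2ccccc2n1` brings one change, ethoxy in place of pyridin-4-yl on an aromatic carbon. Among the compounds with values here, only one measured step bears on this carbon, an at least 6.0-fold lower number from compound 1 to compound 2 (0.78 log units; beyond the scatter), and it shows that the group there can shift the result clearly, though it involved no ethoxy. A somewhat higher number is therefore expected in this assay, with wide uncertainty, and the expected step is a 2.1-fold higher number from compound 2 to compound 3 (0.33 log units; beyond the scatter). Compound 3 is estimated at 3500 nM, within a range of 900 nM to 10000 nM.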

Compound 3, half-maximal inhibitory concentration: > 10000 nM
Compound 3: a limit, no number; the forecaster's own chance of this, stated with the estimate: 25%; at least 2.8-fold (0.45 log units) between middle value and limit.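

In this assay, ethoxy in place of pyridin-4-yl gives an at least 6.0-fold higher number from compound 2 to compound 3 (0.78 log units; beyond the scatter), so pyridin-4-yl now stands apart from both a group with a ring and a group with none. The value of compound 3 is a limit, not a number. Ethoxy and pyridin-4-yl each count one hydrogen-bond acceptor, so that count alone does not decide the result here. The step between compound 1 and compound 3 cannot be read, because both values are limits: the limit of > 10000 nM in this assay, at which 2 of the 3 values shown sit.

Still open, as far as these compounds go, is whether the ring nitrogen of pyridin-4-yl matters, and how a pyridin-3-yl group or an amine on this carbon would behave.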